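A few compounds are considered here, and "the series" means these few. Any claim that something is new, unique, unknown or untested is made for them only; others in the source may bear on it.

In an ADME assay on L02 cells (Homo sapiens) for cytotoxicity, read by MTT assay, with a stated time of 48 h (on this read-out lower numbers stand for stronger inhibition and higher numbers for weaker inhibition), compound 1 `Cc1ccc2[nH]c(=O)c(-c3nc4cc([N+](=O)[O-])ccc4[nH]3)cc2c1` gives > 100000 nM, which is a limit of the assay.
Compound 2 `Cc1ccc2[nH]c(=O)c(-c3nc4cc(C)c(C)cc4[nH]3)cc2c1` gives > 100000 nM, likewise a limit.
Compound 3 `COc1ccc2[nH]c(=O)c(-c3nc4cc([N+](=O)[O-])ccc4[nH]3)cc2c1` gives > 100000 nM, again a limit.

Compound 1 therefore stands only at a limit, and so do the two other compounds; all three sit at the limit of > 100000 nM in this assay, at which 3 of the 3 values shown sit. Within the data shown here, the one step among them, from compound 1 to compound 3, is a step that the two limits leave unreadable from compound 1 to compound 3, so its size cannot be read. Compound 4 `Cc1ccc2[nH]c(=O)c(-c3nc4cc(Br)ccc4[nH]3)cc2c1` differs from compound 1 by bromo in place of nitro on an aromatic carbon. Among the measured compounds shown here, no measured step bears directly on this change, and the limits leave no readable step at all, so the expectation for compound 4 is simply that it stays where compound 1 stands, a step that the limit leaves unreadable from compound 1 to compound 4 in this assay. Compound 4 is thus estimated at 150000 nM, between 50000 nM and 500000 nM, most likely reported only as a limit.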

Compound 4, half-maximal inhibitory concentration: > 100000 nM
Compound 4: only a limit was reported (the forecaster's own chance of this, stated with the estimate: 85%); the middle value is on the limit's open side.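

Among these compounds, compound 4, like compound 1, stands only at a limit, so no step between the two can be read: the limit of > 100000 nM in this assay, at which 4 of the 4 values shown sit. The compounds shown leave open whether bromo in place of nitro, or any other change among them, alters cytotoxicity at all.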